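Turning the Enone Around on a Shared Core

A few compounds are considered here, and "the series" means these few. Any claim that something is new, unique, unknown or untested is made for them only; others in the source may bear on it.

Three measured compounds share one core. In a functional assay on A549 cells (Homo sapiens) for antiproliferative activity, read by MTT assay, with a stated time of 24 h (a lower number here means a stronger inhibitor, a higher number a weaker inhibitor), compound 1 `COc1cc(C(=O)/C=C/c2cc(-c3cc(OC)c(OC)c(OC)c3)n3nc(-c4ccccc4)cc3n2)cc(OC)c1OC` gives 20500 nM, compound 2 `COc1ccc(/C=C/C(=O)c2cc(-c3ccc(OC)c(OC)c3)n3nc(-c4ccccc4)cc3n2)cc1` gives 19300 nM, and compound 3 `COc1ccc(/C=C/C(=O)c2cc(-c3cc(OC)c(OC)c(OC)c3)n3nc(-c4ccccc4)cc3n2)cc1` gives 21200 nM. Compound 2 thus shows the lowest number of the three, yet both neighbours sit within the scatter of it, so no ranking follows. Among the compounds with values here, the only one-place step, a 1.1-fold higher number from compound 2 to compound 3 (0.04 log units; within the scatter), moves nothing beyond the scatter. Compound 4 `COc1ccc(-c2cc(/C=C/C(=O)c3ccc(Cl)cc3)nc3cc(-c4ccccc4)nn23)cc1OC` differs from compound 2 by 2-((4-chlorophenyl)carbonyl)ethenyl in place of (2-(4-methoxyphenyl)ethenyl)carbonyl on an aromatic carbon. Within the data shown here, no measured step covers this change; the step from compound 2 to compound 3 touches only the aryl substituent and stays within the scatter, so nothing beyond the scatter is expected in this assay. Compound 4 is therefore expected to give 19000 nM (range 8000 nM to 45000 nM), a step of a 1.0-fold lower number from compound 2 to compound 4 (0.01 log units; within the scatter).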

Compound 4, half-maximal inhibitory concentration: 15400 nM
Compound 4: the middle estimate sits 1.2-fold (0.09 log units) above what was measured; the range from low to high includes it.
By their numbers in this assay, from the lowest: compounds 4, 2, 1 and 3 (each within the scatter of the next).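

At this position, 2-((4-chlorophenyl)carbonyl)ethenyl in place of (2-(4-methoxyphenyl)ethenyl)carbonyl gives a 1.3-fold lower number from compound 2 to compound 4 (0.10 log units; within the scatter) in this assay. The earlier step touched only the aryl substituent, whereas this one turns the enone around and exchanges its aryl group, yet it too stays within the scatter. Nothing measured offers an explanation for this result.

The shown compounds do not separate the turned enone from the chlorine. Going by these compounds, whether an amine or a carboxylic acid in place of that chlorine would move the number beyond the scatter also remains open.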